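A Pyridine for a Phenyl on the Carbonyl

The source may hold more compounds than are shown below. What is called first, only, known or untested is meant among the compounds shown, and "the series" means these compounds.

Of the compounds shown here, three built on one shared core have been measured in a functional assay (MiaPaCa cells, Homo sapiens) for inhibition, read by sulforhodamine B assay, with a stated time of 48 h; a higher number here means a weaker inhibitor of growth, a lower number a stronger inhibitor of growth. Compound 1 `Nc1ccccc1C(=O)N/N=C/C1=C(Cl)c2ccccc2CCC1` gives 65100 nM. Compound 3 `COc1cc(C(=O)N/N=C/C2=C(Cl)c3cc(C)c(C)cc3CCC2)c([N+](=O)[O-])cc1OC` gives 1600 nM. Compound 2 `Cc1cc2c(cc1C)C(Cl)=C(/C=N/NC(=O)c1ccccc1)CCC2` is different: in this assay compound 2 reaches only > 100000 nM, and that value is a limit of the assay rather than a number. Compound 2 thus sits where the assay stops reporting, (the limit of > 100000 nM in this assay, at which 1 of the 3 values shown sits). Compound 1 and compound 3 do give numbers, and the two lie far apart, but no single-point step connects either of them to compound 2, so only the values themselves can be read, not a cause.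

The untested compound 4 `Cc1cc2c(cc1C)C(Cl)=C(/C=N/NC(=O)c1cccnc1)CCC2` keeps everything in compound 2 except one group: pyridin-3-yl in place of phenyl on a carbonyl carbon. Within the data shown here, no measured pair shows this exchange, so its effect in this assay cannot be taken from the data. Compound 4 is expected to remain a weak inhibitor of growth, with an estimated value of 80000 nM, the likely range running from 20000 nM to 150000 nM. The estimated step of an at least 1.2-fold lower number from compound 2 to compound 4 (0.09 log units; that floor lies within the scatter) is expected to be small, within the usual scatter, with a real chance that compound 4 again returns only a limit.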

Compound 4, concentration for 50% growth inhibition: 1600 nM
The estimate for compound 4 lay 50-fold (1.70 log units) above the measured number; measured number below the stated range.
By their numbers in this assay, from the lowest: compounds 3 and 4 (each within the scatter of the next); then compound 1. At a limit, above all of these: compound 2.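

In this assay, among these compounds, pyridin-3-yl in place of phenyl on a carbonyl carbon gives an at least 62-fold lower number from compound 2 to compound 4 (1.79 log units; beyond the scatter), the first step that ties a change in the number to a single place. The exchange keeps the count of heavy atoms, swaps one ring carbon for a nitrogen and adds one hydrogen-bond acceptor, so this position responds strongly to a change that is small when counted in atoms, although the data do not say which feature of the new ring accounts for the step. Compound 2 gives only a limit, so the step is a floor and its full size stays unknown: the limit of > 100000 nM in this assay, at which 1 of the 4 values shown sits.

The compounds shown leave open whether other groups on the same carbonyl carbon, such as a pyrimidine ring, a thiophene ring or a simple alkyl chain, would give a step of similar size. They also leave open whether the same exchange of phenyl for pyridin-3-yl would give a comparable step on the core of compound 1.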